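A few compounds are considered here, and "the series" means these few. Any claim that something is new, unique, unknown or untested is made for them only; others in the source may bear on it.

Measured in an ADME assay (liver, Mus musculus) for metabolic stability, using microsomes; on this read-out higher numbers stand for a longer-lived compound and lower numbers for a shorter-lived compound:
- compound 1 `CCc1nc2cc(Cl)ccn2c1C(=O)NCc1ccc(-c2ccc(C)cc2)cc1`: 0.385 h
- compound 2 `CCc1nc2cc(Cl)ccn2c1C(=O)NCc1ccc(N2CCCCCC2)cc1`: 0.0317 h

Within the data shown here, compound 1 holds the higher of the two numbers, and compound 2 is the only neighbour to compare it with. Compound 3 `CCc1nc2cc(Cl)ccn2c1C(=O)NCc1ccc(N2CCN(C(C)C)CC2)cc1` has not been measured. It carries 4-isopropylpiperazin-1-yl in place of 4-methylphenyl on an aromatic carbon.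

Among the measured compounds shown here, one measured step bears on this change: a 12-fold lower number from compound 1 to compound 2 (1.08 log units; beyond the scatter). That step is large and beyond the scatter, and there azepan-1-yl replaces the same 4-methylphenyl. Both incoming groups are non-aromatic rings, but a single step sets no pattern and the two rings differ, so the size carries over only loosely. The expected step is a 5.5-fold lower number from compound 1 to compound 3 (0.74 log units; beyond the scatter), in the same downward direction and probably beyond the scatter. For compound 3 the estimated half-life is 0.07 h, with an expected range of 0.025 h to 0.2 h.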

Compound 3, half-life: 0.148 h
The estimate for compound 3 lay 2.1-fold (0.33 log units) below the measured number; low and high end bracket the measured number.
By their numbers in this assay, from the lowest: compound 2; then compound 3; then compound 1.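

In this assay a second non-aromatic ring on this aromatic carbon also falls short of 4-methylphenyl, with a 2.6-fold lower number from compound 1 to compound 3 (0.42 log units; beyond the scatter), so both replacements shown run in the same direction. The size of the loss depends on which ring enters: 4-isopropylpiperazin-1-yl in place of azepan-1-yl gives a 4.7-fold higher number from compound 2 to compound 3 (0.67 log units; beyond the scatter), which places compound 3 between the other two compounds. No measurement at hand accounts for the gap between the two rings.

The compounds shown do not separate the contribution of the ring nitrogens in 4-isopropylpiperazin-1-yl from that of its isopropyl group, which a morpholine ring or a piperazine carrying methyl or acetyl in place of isopropyl would address. On these data alone, it also stays open whether any non-aromatic ring here can match 4-methylphenyl, or whether a pyridine ring would hold the number of compound 1.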